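This account rests on a few compounds, and the source may have more. Where it says the series, first, only, none or still open, it means among the compounds named here.

Measured compounds:
- Compound 1, `Cc1cc(N2CC[C@H](N3CCC[C@@H]3C)C2)ccc1NC(=O)c1ccoc1`: 1.8 nM
- Compound 2, `Cc1cc(N2CC[C@H](N3CCC[C@@H]3C)C2)ccc1NC(=O)c1cc(C)n(C)n1`: 10.8 nM
- Compound 3, `Cc1nc(N2CC[C@H](N3CCC[C@@H]3C)C2)ccc1NC(=O)c1ccccc1`: 3 nM

All three were tested in an assay on CHO cells for displacement of a labelled ligand from histamine receptor H3 (Macaca mulatta), read by scintillation counting, with a stated time of 1 h; on this read-out lower numbers stand for stronger inhibition and higher numbers for weaker inhibition. Compound 2 gives the highest of the three numbers: compound 1 sits a 6.0-fold higher number from compound 1 to compound 2 (0.78 log units; beyond the scatter) away, a change that arose when the furan-3-yl group on the carbonyl carbon was exchanged for 1,5-dimethyl-1H-pyrazol-3-yl, so the piece attached to the carbonyl clearly matters here. Compound 3, which carries a different core and a plain phenyl on the carbonyl, lies between the two.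

Compound 4, `Cc1cccc(C(=O)Nc2ccc(N3CC[C@H](N4CCC[C@@H]4C)C3)cc2C)n1`, differs from compound 2 in exactly that place: 6-methylpyridin-2-yl in place of 1,5-dimethyl-1H-pyrazol-3-yl on a carbonyl carbon. Among the measured compounds shown here, the only measured step that bears on this, a 6.0-fold higher number from compound 1 to compound 2 (0.78 log units; beyond the scatter), shows that swapping the aromatic group on the carbonyl can shift the number by a modest amount. Since compound 1 and compound 3 both carry aromatic groups other than the pyrazole and both give lower numbers than compound 2, a modest drop in the number is expected for compound 4, a 2.7-fold lower number from compound 2 to compound 4 (0.43 log units; beyond the scatter). The estimate for compound 4 in this assay is 4 nM, within a range of 1.5 nM to 12 nM.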

Compound 4, inhibition constant: 1.4 nM
Compound 4: middle estimate off by 2.9-fold (0.46 log units), on the high side, outside the stated range (below it).
By their numbers in this assay, from the lowest: compounds 4, 1 and 3 (each within the scatter of the next, the first and the last beyond it); then compound 2.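

In this assay, placing 6-methylpyridin-2-yl on the carbonyl carbon in place of 1,5-dimethyl-1H-pyrazol-3-yl gives a clear change (a 7.7-fold lower number from compound 2 to compound 4 (0.89 log units; beyond the scatter)), so a second exchange at this position now moves the number beyond the scatter. Against furan-3-yl the same group makes no readable difference (a 1.3-fold lower number from compound 1 to compound 4 (0.11 log units; within the scatter)), which leaves compound 2 alone at the high end among the three compounds on this core, and ring size does not sort them, since the low numbers come with both a five-membered and a six-membered ring. No measured evidence here accounts for the higher number of the 1,5-dimethyl-1H-pyrazol-3-yl group.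

On these data alone, it remains open whether the methyl groups on these rings contribute, as a plain pyridin-2-yl or a pyrazole without methyl groups on the same carbonyl carbon would show. Whether an aromatic ring is needed at all is also unsettled, and a saturated group such as cyclohexyl at this place would address that.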